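Adding a methyl to the butyl chain of compound 2

A few compounds are considered here, and "the series" means these few. Any claim that something is new, unique, unknown or untested is made for them only; others in the source may bear on it.

Compound 2 `CCCCc1nc(=O)c(S(=O)(=O)c2ccc(-c3ccc(F)nc3)cc2)c(O)n1-c1c(OC)cccc1OC` and compound 1 `CCCCc1nc(=O)c(S(=O)(=O)c2ccc(-c3ccnc(NC(=O)C4CC4)c3)cc2)c(O)n1-c1c(OC)cccc1OC` share a core and differ only in one aromatic group. In an ADME assay on microsomes from liver (Mus musculus) for metabolic stability, using NADPH, with a stated time of 10 min (on this read-out lower numbers stand for a less stable compound and higher numbers for a more stable compound), compound 1 gives 72%, and compound 2 gives 69%, a pair separated by a number 3 percentage points lower from compound 1 to compound 2 (within the scatter). Compound 3 `COc1cccc(OC)c1-n1c(CCC(C)C)nc(=O)c(S(=O)(=O)c2ccc(-c3ccc(F)nc3)cc2)c1O` differs from compound 2 by methyl in place of hydrogen on a saturated chain carbon bound to two saturated chain carbons. Within the data shown here, no measured pair shows this change; the one known step touches the aromatic side. Compound 3 is therefore expected to sit close to compound 2, with an expected step of a number 4 percentage points lower from compound 2 to compound 3 (within the scatter), and its estimated value is 65%, between 45% and 85%.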

Compound 3, percent of the compound remaining: 31%
For compound 3 the middle estimate is 34 percentage points above the measured one; the measured number lies below the stated range.
By their numbers in this assay, from the lowest: compound 3; then compounds 2 and 1 (each within the scatter of the next).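

In this assay, going from butyl to isopentyl gives a number 38 percentage points lower from compound 2 to compound 3 (beyond the scatter). So one added methyl on a saturated chain carbon bound to two saturated chain carbons can move this read-out far beyond the scatter, which the earlier aromatic change did not do. Nothing available explains this drop. As far as these compounds go, whether a longer chain, or a hydroxyl group on that carbon, would behave the same stays open. So does whether the methyl would matter as much alongside the 2-((cyclopropylcarbonyl)amino)pyridin-4-yl group of compound 1.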